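Amide nitrogen substituent change, compound 2 to compound 4

The source may hold more compounds than are shown below. What is called first, only, known or untested is meant among the compounds shown, and "the series" means these compounds.

Three compounds have so far been run in a functional assay on PC-3 cells (Homo sapiens) for cytotoxicity, read by MTT assay, with a stated time of 72 h; a higher number here means a weaker inhibitor, a lower number a stronger inhibitor. Compound 1 `COc1ccc(/C=C/C(=O)OCC(=O)Nc2ccccc2)cc1OC` returns only a limit, > 200000 nM. Compound 2 `COCOc1cc(/C=C/C(=O)OCC(=O)NCc2ccco2)ccc1OCc1ccccc1` likewise returns only a limit, > 200000 nM. Compound 3 `CCOc1ccc(COc2c(OC)cc(/C=C/C(=O)OCC(=O)Nc3ccccc3)cc2OC)cc1` also returns only a limit, > 200000 nM. No numbered value has been reached for any of them, so compound 2 stands at the same limit as the other two and no ordering among the three can be stated; the limit of > 200000 nM in this assay, at which 3 of the 3 values shown sit, sums up the position of the whole set.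

Compound 4 `COCOc1cc(/C=C/C(=O)OCC(=O)Nc2ccc(Cl)cc2)ccc1OCc1ccccc1` has not yet been run in this assay. It differs from compound 2 in one place: 4-chlorophenyl in place of (furan-2-yl)methyl on an amide-type nitrogen. Going by the values given here, no step between measured compounds exists in this set, so there is no measured basis for a direction; the expectation is no step beyond the scatter, with compound 4 most likely returning a further limit rather than a number.

Compound 4 is expected to give 250000 nM, within 100000 nM to 600000 nM. The step is expected as a step that the limit leaves unreadable from compound 2 to compound 4, meaning essentially no change.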

Compound 4, half-maximal inhibitory concentration: > 200000 nM
Compound 4: no number, only a limit; the forecaster's own chance of this, stated with the estimate: 85%; the middle value is on the limit's open side.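

In this assay compound 4 returns > 200000 nM as a limit only. Compound 2 also stands at a limit, so no step can be read for this change on the amide-type nitrogen. The compounds shown leave open whether any member of the series reaches a numbered value in this assay at all.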